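A few compounds are considered here, and "the series" means these few. Any claim that something is new, unique, unknown or untested is made for them only; others in the source may bear on it.

Compound 1 `O=C(/C=C/c1cccc(NC(=O)c2ccccc2Cl)c1)c1nc2ccccc2[nH]1`: 1280 nM
Compound 2 `O=C(Nc1cccc(/C=C/C(=O)c2nc3ccccc3[nH]2)c1)c1cccc(Cl)c1`: 1120 nM
Compound 3 `O=C(/C=C/c1cccc(NC(=O)c2ccccc2Br)c1)c1nc2ccccc2[nH]1`: 1680 nM

These three compounds share one core and differ only in the aryl group on the amide carbonyl. In a functional assay on HCT-116 cells (Homo sapiens) for antiproliferative activity, read by MTT assay, with a stated time of 48 h (on this read-out lower numbers stand for stronger inhibition and higher numbers for weaker inhibition), compound 3 gives the highest of the three numbers, but its steps to the other two, a 1.3-fold higher number from compound 1 to compound 3 (0.12 log units; within the scatter) and a 1.5-fold higher number from compound 2 to compound 3 (0.18 log units; within the scatter), both lie within the scatter, so no order among the three can be read from these data.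

Compound 4 `Cc1cccc(C(=O)Nc2cccc(/C=C/C(=O)c3nc4ccccc4[nH]3)c2)c1` follows from compound 3 by the change (3-methylphenyl in place of 2-bromophenyl on a carbonyl carbon). Among the measured compounds shown here, three measured steps bear on this. The step of a 1.1-fold lower number from compound 1 to compound 2 (0.06 log units; within the scatter) moves a chloro from one ring position to another; the step of a 1.3-fold higher number from compound 1 to compound 3 (0.12 log units; within the scatter) exchanges one halogen for another; and the step of a 1.5-fold higher number from compound 2 to compound 3 (0.18 log units; within the scatter) exchanges a whole halophenyl for a differently substituted halophenyl. None of these moves the number beyond the scatter. For the measured compounds named here, the replacement of the halogen by a methyl group has no measured precedent in this set, so the expectation for compound 4 rests on the indifference seen so far.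

On that basis the step of a 1.2-fold lower number from compound 3 to compound 4 (0.08 log units; within the scatter) is expected to stay within the scatter. In this assay compound 4 is therefore estimated at 1400 nM, with a range from 700 nM to 2800 nM.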

Compound 4, half-maximal inhibitory concentration: 1420 nM
Compound 4: the middle estimate sits 1.0-fold (0.01 log units) below what was measured; measured number inside the range.
By their numbers in this assay, from the lowest: compounds 2, 1, 4 and 3 (each within the scatter of the next).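

In this assay, the methyl group of compound 4 extends the tolerated substituents on this aryl ring beyond halogens: replacing chloro with methyl on the aromatic carbon gives the step (a 1.3-fold higher number from compound 2 to compound 4 (0.10 log units; within the scatter)). This is the most direct comparison. It keeps the 3-substituted phenyl pattern. The two changes that also alter the ring position, (a 1.1-fold higher number from compound 1 to compound 4 (0.05 log units; within the scatter)) and (a 1.2-fold lower number from compound 3 to compound 4 (0.07 log units; within the scatter)), likewise stay within the scatter, so among these four compounds the aryl group on the amide carbonyl can carry a halogen or a methyl without a readable change in the number. No measurement shown here explains why these numbers lie so close together.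

The compounds shown leave open whether an amine, a carboxylic acid, a methoxy group or a longer alkyl chain on this ring would stay equally close, or whether any such group would move the number beyond the scatter. They also leave open how an unsubstituted phenyl would compare, and whether this indifference would hold if the shared core were changed.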